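Three Growth Inhibitors at One Level, and a Fourth to Test

The compounds below may be only part of what the source reports. "The series", "measured", "known", "first", "only" and "open" are said of these compounds alone.

Compound 1 `O=C(/C(=C\c1csc([N+](=O)[O-])c1)S(=O)(=O)c1ccc(Br)cc1)c1ccc(Br)cc1` was tested in a functional assay on DU-145 cells (Homo sapiens) for inhibition, read by trypan blue exclusion, with a stated time of 96 h (a lower number here means a stronger inhibitor of growth, a higher number a weaker inhibitor of growth), where compound 1 gives 1000 nM. Two companions share the same carbonyl-bearing core. Compound 2 `COc1ccc(/C=C(/SCc2ccc(F)cc2)C(=O)c2ccc(Br)cc2)cc1O` gives 1000 nM in this assay, and compound 3 `Cc1ccc(S(=O)(=O)/C(=C/c2ccccc2OCc2ccccc2)C(=O)c2ccc(Br)cc2)cc1` gives 1000 nM. At the digits printed compound 1 stands level with compound 2 and with compound 3, and none of these pairs is separated by more than the usual scatter, so no ordering among the three can be read from these numbers.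

Compound 4 `O=C(/C(=C\c1ccc(Cl)c([N+](=O)[O-])c1)S(=O)(=O)c1ccc(Br)cc1)c1ccc(Br)cc1` has not yet been measured. It differs from compound 1 in one place: 4-chloro-3-nitrophenyl in place of 5-nitrothiophen-3-yl on a double-bonded chain carbon bound to a double-bonded chain carbon. Going by the values given here, no measured pair in this set shows a change of this kind, so there is no step to lean on. Given that compound 1, compound 2 and compound 3 all sit at the same level, the step from compound 1 to compound 4 is expected to be small, no change at the digits printed from compound 1 to compound 4 (within the scatter), with no clear direction beyond the scatter. Compound 4 is therefore expected to give about 1000 nM in this assay, within a range from 300 nM to 3000 nM.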

Compound 4, concentration for 50% growth inhibition: 10000 nM
The estimate for compound 4 lay 10-fold (1.00 log units) below the measured number, outside the stated range (above it).
By their numbers in this assay, from the lowest: compounds 1, 2 and 3 (each within the scatter of the next); then compound 4.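

In this assay, putting 4-chloro-3-nitrophenyl in place of 5-nitrothiophen-3-yl on a double-bonded chain carbon bound to a double-bonded chain carbon gives a 10-fold higher number from compound 1 to compound 4 (1.00 log units; beyond the scatter), a weaker inhibitor of growth even though both groups carry a nitro group. Going by these compounds alone, the earlier compounds offered no pair differing in one place, so only this step shows that the number responds to a change at this position. No measurement given here explains the step.

The swap changes the ring size, adds a chlorine and alters the ring's atoms all at once, and a single step cannot separate these changes. On these data alone, it also remains open whether an amine or a carboxylic acid in place of the chlorine would give a number closer to that of compound 1 or compound 4.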